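From 4-methylphenyl to 4-chlorophenyl: working notes

This account rests on a few compounds, and the source may have more. Where it says the series, first, only, none or still open, it means among the compounds named here.

In a functional assay on MOLT-4 cells (Homo sapiens) for antiproliferative activity, read by cell counting, with a stated time of 2 days (on this read-out lower numbers stand for stronger inhibition and higher numbers for weaker inhibition), compound 1 (`COc1cc(C(=O)c2sc(Nc3ccccc3)nc2N)cc(OC)c1OC`) gives 6 nM and compound 2 (`COc1cc(C(=O)c2sc(Nc3ccc(F)cc3)nc2N)cc(OC)c1OC`) gives 280 nM while compound 3 (`COc1cc(C(=O)c2sc(Nc3ccc(C)cc3)nc2N)cc(OC)c1OC`) gives 21 nM and so holds the middle place of the three numbers, nearer compound 1 than compound 2. Compound 4 (`COc1cc(C(=O)c2sc(Nc3ccc(Cl)cc3)nc2N)cc(OC)c1OC`) awaits measurement. It differs from compound 3 by chloro in place of methyl on an aromatic carbon, para to a large group (chloro in place of methyl on an aromatic carbon).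

Among the compounds with values here, three measured steps bear on this change. Methyl in place of hydrogen gives a modest rise (a 3.5-fold higher number from compound 1 to compound 3 (0.54 log units; beyond the scatter)), fluoro in place of hydrogen a large one (a 47-fold higher number from compound 1 to compound 2 (1.67 log units; beyond the scatter)), and methyl in place of fluoro a large fall (a 13-fold lower number from compound 2 to compound 3 (1.12 log units; beyond the scatter)). Within the data shown here, both substituted compounds sit above compound 1, and no measured compound goes against this, but only two groups have been tested and no chloro compound has been measured. Chloro is a halogen like the fluoro of compound 2 (280 nM), so some movement towards that number is expected, short of the full distance. A modest rise is expected in this assay (a 2.9-fold higher number from compound 3 to compound 4 (0.46 log units; beyond the scatter)). Compound 4 is estimated at 60 nM with a range from 15 nM to 250 nM as its expected span.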

Compound 4, half-maximal inhibitory concentration: 110 nM
For compound 4 the middle estimate is 1.8-fold (0.26 log units) below the measured one; the range from low to high includes it.
By their numbers in this assay, from the lowest: compound 1; then compound 3; then compound 4; then compound 2.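

With an 18-fold higher number from compound 1 to compound 4 (1.26 log units; beyond the scatter) in this assay a third group at this position joins the methyl and fluoro compounds above the unsubstituted compound 1, and no compound shown goes against this. The measured order from the lowest number now runs hydrogen, methyl, chloro, fluoro, and the step of a 5.2-fold higher number from compound 3 to compound 4 (0.72 log units; beyond the scatter) places both halogen compounds above the methyl compound. The two halogens do not read alike at this position either, since a 2.5-fold lower number from compound 2 to compound 4 (0.41 log units; beyond the scatter) shows a gap beyond the scatter, so being a halogen does not by itself set the number here.

No measurement in hand accounts for this order of the four groups. Open questions are whether bromo would continue the halogen series, and whether methoxy, an amine or a carboxylic acid in the same place would also stand above compound 1 or would come closer to it.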